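The source may hold more compounds than are shown below. What is called first, only, known or untested is meant among the compounds shown, and "the series" means these compounds.

The three measured compounds share one core and differ only in the group on a saturated ring carbon. Compound 1 `CC1=C(C(=O)Nc2ccc(F)c(Cl)c2)C(c2ccccc2Cl)NC(=S)N1` gives 16600 nM in a functional assay on NCI/ADR-RES cells (Homo sapiens) for cytotoxicity, read by sulforhodamine B assay, with a stated time of 48 h; a lower number here means a stronger inhibitor of growth, a higher number a weaker inhibitor of growth. Compound 2 `CC1=C(C(=O)Nc2ccc(F)c(Cl)c2)C(c2cccc(Cl)c2)NC(=S)N1` gives 15800 nM in this assay, and the change between them, 3-chlorophenyl in place of 2-chlorophenyl, reads a 1.1-fold lower number from compound 1 to compound 2 (0.02 log units; within the scatter). Compound 3 `CC1=C(C(=O)Nc2ccc(F)c(Cl)c2)C(c2cccc(Oc3ccccc3)c2)NC(=S)N1` gives 15500 nM in this assay, with phenoxy in place of chloro on an aromatic carbon, a change that reads a 1.0-fold lower number from compound 2 to compound 3 (0.01 log units; within the scatter). Compound 3 therefore stands within the scatter of both compound 1 and compound 2; the three numbers cannot be told apart.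

Compound 4 `COc1cccc(C2NC(=S)NC(C)=C2C(=O)Nc2ccc(F)c(Cl)c2)c1` has not yet been measured. It differs from compound 3 in one place: methyl in place of phenyl on an oxygen on an aromatic ring. Among the measured compounds shown here, no measured step exchanges methyl for phenyl on an oxygen. For the measured compounds named here, the only step that touches the same aromatic carbon is the one from compound 2 to compound 3, and it stayed within the scatter, since a 1.0-fold lower number from compound 2 to compound 3 (0.01 log units; within the scatter) is all that phenoxy in place of chloro produced. Because a 1.0-fold lower number from compound 2 to compound 3 (0.01 log units; within the scatter) showed no movement at this position, no step beyond the scatter is expected for compound 4 in this assay, in no particular direction. For compound 4 the expected step is a 1.0-fold higher number from compound 3 to compound 4 (0.01 log units; within the scatter). Compound 4 is accordingly estimated at 16000 nM, with a range from 8000 nM to 32000 nM.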

Compound 4, concentration for 50% growth inhibition: 15500 nM
Compound 4: middle estimate off by 1.0-fold (0.01 log units), on the high side; low and high end bracket the measured number.
By their numbers in this assay, from the lowest: compounds 3, 4, 2 and 1 (each within the scatter of the next).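

In this assay, phenoxy to methoxy takes a whole six-membered aromatic ring of carbon only out of the group on this aromatic carbon and leaves methyl on the oxygen, and the result is no change at the digits printed from compound 3 to compound 4 (within the scatter). Methoxy in place of chloro on the same carbon gives a 1.0-fold lower number from compound 2 to compound 4 (0.01 log units; within the scatter), and 3-methoxyphenyl in place of 2-chlorophenyl on the saturated ring carbon gives a 1.1-fold lower number from compound 1 to compound 4 (0.03 log units; within the scatter), so chloro, phenoxy and methoxy on this carbon cannot be told apart here, and removing the phenyl from the oxygen does not move the number beyond the scatter. Nothing available bears on why these numbers stay together.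

The compounds shown leave open whether an amine or a carboxylic acid on this aromatic carbon, or a longer chain in place of methyl on the oxygen, would move the number beyond the scatter. They also leave open whether these exchanges would read the same way with a group other than the chlorofluorophenyl on the amide.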